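A few compounds are considered here, and "the series" means these few. Any claim that something is new, unique, unknown or untested is made for them only; others in the source may bear on it.

Working notes on the hydrazone series.

The shared core is seen in compound 1 `Cc1c(C(=O)N/N=C\c2ccco2)oc2cccc(O)c12`. In a functional assay on PC-3 cells (Homo sapiens) for inhibition (on this read-out higher numbers stand for weaker inhibition and lower numbers for stronger inhibition), compound 1 reaches only the limit >= 40000 nM. Compound 2 `Cc1c(C(=O)N/N=C\c2ccc(C(F)(F)F)cc2)oc2cccc(O)c12` likewise sits at the limit >= 40000 nM in this assay. Compound 3 `Cc1c(C(=O)N/N=C\c2ccncc2)oc2cccc(O)c12` gives the limit >= 40000 nM in this assay. The step that the two limits leave unreadable from compound 1 to compound 3 cannot be read because both its ends are limits (the limit of >= 40000 nM in this assay, at which 3 of the 3 values shown sit). Compound 3 therefore stands where every measured compound in the series stands: at the limit, with no ordering among compounds 1, 2 and 3 possible from these numbers.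

Compound 4 `Cc1c(C(=O)N/N=C\c2ccc(F)cc2)oc2cccc(O)c12` is not yet measured. Compared with compound 3 it carries 4-fluorophenyl in place of pyridin-4-yl on a carbon with a double bond to nitrogen. Among the measured compounds shown here, the only measured step at this carbon with a double bond to nitrogen, a step that the two limits leave unreadable from compound 1 to compound 3, gives no readable size because both compounds sit at the limit (the limit of >= 40000 nM in this assay, at which 3 of the 3 values shown sit); compound 2, with another aryl group at the same place, also gave only a limit. Nothing measured separates the aryl groups tried so far, so no step beyond the scatter is expected in this assay, and the expected step is a number no higher from compound 3 to compound 4 (the limit leaves the size open). Compound 4 is estimated at 40000 nM, with a range of 20000 nM to 80000 nM, and a limit rather than a number is the likeliest outcome.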

Compound 4, half-maximal inhibitory concentration: >= 40000 nM
Compound 4: no number, only a limit; the forecaster's own chance of this, stated with the estimate: 85%; the middle value sits exactly at the limit.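

In this assay compound 4 gives >= 40000 nM, a limit and not a number. No step from compound 1, compound 2 or compound 3 to compound 4 can be read: the limit of >= 40000 nM in this assay, at which 4 of the 4 values shown sit.

The compounds shown leave open whether any group on this carbon with a double bond to nitrogen gives a readable value, and how compounds 1 to 4 rank.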